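Adding a 4-methoxyphenyl to the core of compound 2

The source may hold more compounds than are shown below. What is called first, only, known or untested is meant among the compounds shown, and "the series" means these compounds.

Among the compounds with values here, compound 2 `O=C(CCCCC1CCSS1)NCc1cn(CCCCCOc2ccc3ccc(=O)oc3c2)nn1` is one of three compounds measured in a functional assay on PC-12 cells (Rattus norvegicus) for cytotoxicity, read by MTT assay, with stated times of 3 h and 2 h, tested at 1 uM; on this read-out lower numbers stand for a weaker effect and higher numbers for a stronger effect at the one concentration tested. In this assay compound 2 gives 57.2%. Compound 3 `Cc1cc(=O)oc2cc(OCCCCCn3cc(CNC(=O)CCCCC4CCSS4)nn3)ccc12` gives 56.5%, and compound 1 `O=C(CCCCC1CCSS1)NCc1cn(CCCCOc2ccc3cc(-c4ccc(Cl)c(Cl)c4)c(=O)oc3c2)nn1` gives 49.3%; both numbers lie within the usual scatter of the number for compound 2, so the three measured compounds cannot be told apart on this read-out.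

Compound 4 `COc1ccc(-c2cc3ccc(OCCCCCn4cc(CNC(=O)CCCCC5CCSS5)nn4)cc3oc2=O)cc1` has not yet been measured. It differs from compound 2 in one place: 4-methoxyphenyl in place of hydrogen on an aromatic carbon. The new group sits on an aromatic carbon of a six-membered aromatic ring with one oxygen, part of a fused system of two rings.

Within the data shown here, only one measured step changes a single place on the same core, and it is small: a number 0.7 percentage points lower from compound 2 to compound 3 (within the scatter). Among the measured compounds shown here, compound 1 also carries an aryl group on its core, but it differs from compound 2 in more than one place, so no step between the two has been computed. Compound 2 gives 57.2%, and compound 1 gives 49.3%; the two numbers can only be set side by side. On this basis the step of a number 4.2 percentage points lower from compound 2 to compound 4 (within the scatter) is expected to stay within the scatter. Compound 4 is therefore estimated to give 53%, in a range from 41% to 65%.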

Compound 4, a percentage reported as activity, at one concentration (the size of the read-out at that concentration, not a potency): 37.1%
The estimate for compound 4 lay 15.9 percentage points above the measured number; the whole stated range lies above it.
By their numbers in this assay, from the lowest: compound 4; then compounds 1, 3 and 2 (each within the scatter of the next).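

Placing 4-methoxyphenyl on this aromatic carbon of the six-membered aromatic ring with one oxygen gives a number 20.1 percentage points lower from compound 2 to compound 4 (beyond the scatter) in this assay and shows that the read-out can respond to a single change on the shared core. Within the data shown here, the only earlier step of this kind, a number 0.7 percentage points lower from compound 2 to compound 3 (within the scatter) for a methyl in place of hydrogen on an aromatic carbon, had given no such sign, and lower numbers here stand for a weaker effect at the one concentration tested, so this change weakens the effect without saying anything about potency. Nothing in the data shown explains why the number falls.

The compounds shown leave open whether a plain phenyl without the methoxy, or a phenyl carrying a hydroxyl or an amine instead, would give a step of similar size at this carbon. From the compounds shown here alone, it also remains open whether the same step would appear at other concentrations or with the 4-methoxyphenyl on a core with a different chain.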